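Cytotoxicity of a triazole amide series: a ring replaces methyl

This account rests on a few compounds, and the source may have more. Where it says the series, first, only, none or still open, it means among the compounds named here.

The compounds here share one core, carrying a benzyl group and an amide link to a thioamide-containing bicyclic fragment. Compound 1 `CCn1nc(C(=O)N[C@H]2COc3ccccc3N(C)C2=S)nc1Cc1ccccc1` bears an ethyl group on the aromatic nitrogen of the triazole. In a toxicity assay on HT-29 cells (Homo sapiens) for cytotoxicity (a higher number here means that more compound is tolerated, a lower number that less compound is tolerated), compound 1 gives > 100000 nM, which is a limit of the assay rather than a number. Compound 2 `CN1C(=S)[C@@H](NC(=O)c2nc(Cc3ccccc3)n(CCCC#N)n2)COc2ccccc21` gives > 100000 nM, again a limit. Compound 3 `CN1C(=S)[C@@H](NC(=O)c2nc(Cc3ccccc3)n(CCCCCC#N)n2)COc2ccccc21` gives > 100000 nM, also a limit. Because the limit of > 100000 nM in this assay, at which 3 of the 3 values shown sit, holds for all three, the steps a step that the two limits leave unreadable from compound 1 to compound 2, a step that the two limits leave unreadable from compound 1 to compound 3 and a step that the two limits leave unreadable from compound 2 to compound 3 cannot be sized.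

Compound 4 `CN1C(=S)[C@@H](NC(=O)c2nc(Cc3ccccc3)n(CC3CCOCC3)n2)COc2ccccc21` differs from compound 1 by oxan-4-yl in place of methyl on a saturated chain carbon bound to an aromatic nitrogen. Among the compounds with values here, no measured step tells how such a change plays out in this assay; the chain extensions from compound 1 to compounds 2 and 3 simply left both partners at the limit. The expectation is therefore that compound 4 also sits at the limit, with a number no higher from compound 1 to compound 4 (the limit leaves the size open) expected to show no step beyond the scatter. Compound 4 is estimated at 100000 nM, in the range 50000 nM to 300000 nM.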

Compound 4, half-maximal cytotoxic concentration: > 100000 nM
Compound 4: a limit, no number (the forecaster's own chance of this, stated with the estimate: 80%); the middle value lies on the limit itself.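

Compound 4 also sits at a limit, so its steps from compound 1, compound 2 and compound 3 cannot be read in this assay here: the limit of > 100000 nM in this assay, at which 4 of the 4 values shown sit.

The compounds shown leave open whether the groups on the triazole nitrogen differ at all in this assay once numbers replace limits.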